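This account rests on a few compounds, and the source may have more. Where it says the series, first, only, none or still open, it means among the compounds named here.

Among the measured compounds shown here, in an assay on Sf9 cells for inhibition of protein deacetylase HDAC6 (Homo sapiens), read by fluorescence, with a stated time of 40 min, tested at 100 nM (on this read-out higher numbers stand for more inhibition at the one concentration tested (going by the name of the read-out) and lower numbers for less inhibition), compound 1 `O=C(NO)c1ccc(NCc2nc(-c3ccccc3)nn2-c2cccc(Cl)c2)cc1` gives 62.3%, the higher of the two numbers measured so far. Compound 2 `NNC(=O)c1ccc(NCc2nc(-c3ccccc3)nn2-c2ccccc2)cc1` gives 10% in this assay, a number beyond the usual scatter below that of compound 1; the two structures differ in more than one place, so their values show only the size of the gap. Compound 3 `O=C(NO)c1ccc(NCc2nc(-c3ccccc3)nn2-c2ccc(Br)cc2)cc1` remains to be measured. It differs from compound 1 by 4-bromophenyl in place of 3-chlorophenyl on an aromatic nitrogen. For the measured compounds named here, no single-place step has been measured, so the expected step is a number 2.3 percentage points lower from compound 1 to compound 3 (within the scatter), within the scatter. Compound 3 is expected to give about 60%, between 40% and 80%.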

Compound 3, a percentage reported as inhibition, at one concentration (the size of the read-out at that concentration, not a potency): 65.9%
Compound 3: middle estimate off by 5.9 percentage points, on the low side, within the range that was stated.
By their numbers in this assay, from the lowest: compound 2; then compounds 1 and 3 (each within the scatter of the next).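

In this assay, among the compounds shown here, the change to 4-bromophenyl in place of 3-chlorophenyl on the aromatic nitrogen comes to a number 3.6 percentage points higher from compound 1 to compound 3 (within the scatter) and gives the first single-place comparison. This position therefore carries either of these two halogen-bearing phenyl groups with no difference that the assay can separate. The halogen and its place on the ring changed together, so neither can be judged alone, and nothing measured here bears on why the two read alike. As far as these compounds go, it remains open whether 4-chlorophenyl would read the same, and whether an amine or a carboxylic acid on this phenyl ring would keep the inhibition.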